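Nitro placement on the aromatic ring and antiproliferative activity

The source may report more compounds than this note shows. Statements on the series, on what has been measured and on what is new or still open speak of the compounds shown alone.

Two measured compounds share one core and differ only in the group on the aromatic ring attached to the double-bonded chain. Compound 1 `COc1ccc(C(=O)/C=C/c2ccc(N(C)C)cc2)c2c1C=CC(C)(C)O2` carries a dimethylamino group there; in a functional assay on SW-620 cells (Homo sapiens) for antiproliferative activity, read by MTT assay, with a stated time of 24 h (on this read-out higher numbers stand for weaker inhibition and lower numbers for stronger inhibition), compound 1 gives 570 nM. Compound 2 `COc1ccc(C(=O)/C=C/c2ccc([N+](=O)[O-])cc2)c2c1C=CC(C)(C)O2` carries a nitro group instead, and in this assay compound 2 gives 3520 nM, the higher of the two numbers, so it is the weaker inhibitor of the pair. Among the measured compounds shown here, the only measured step, a 6.2-fold higher number from compound 1 to compound 2 (0.79 log units; beyond the scatter), is a swap of one group for another at the same place on that ring.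

Compound 3 `COc1ccc(C(=O)/C=C/c2cccc([N+](=O)[O-])c2)c2c1C=CC(C)(C)O2` differs from compound 2 by 3-nitrophenyl in place of 4-nitrophenyl on a double-bonded chain carbon bound to a double-bonded chain carbon. For the measured compounds named here, no measured step concerns where the nitro group sits on that ring; the single step measured concerns which group is present. Nothing in the data therefore points to a direction, and a change no larger than the usual scatter is expected. Compound 3 is expected to give about 3500 nM, in a range from 1200 nM to 9000 nM. The expected step is a 1.0-fold lower number from compound 2 to compound 3 (0.00 log units; within the scatter).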

Compound 3, half-maximal inhibitory concentration: 4090 nM
For compound 3 the middle estimate is 1.2-fold (0.07 log units) below the measured one, and the stated range covers the measured number.
By their numbers in this assay, from the lowest: compound 1; then compounds 2 and 3 (each within the scatter of the next).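

In this assay, 3-nitrophenyl in place of 4-nitrophenyl gives a 1.2-fold higher number from compound 2 to compound 3 (0.07 log units; within the scatter), so these two placements of the nitro group cannot be told apart on this evidence. Compound 1 remains separate from both nitro compounds: 3-nitrophenyl in place of 4-(dimethylamino)phenyl gives a 7.2-fold higher number from compound 1 to compound 3 (0.86 log units; beyond the scatter), and the earlier step to the other nitro compound was also beyond the scatter. Within these three compounds, then, the choice between dimethylamino and nitro is tied to a measurable difference, while the shift of the nitro group is not, and nothing measured here speaks to the reason for either result.

It remains open whether moving the dimethylamino group around the ring would matter more than moving the nitro group did, since only one placement of dimethylamino is shown. As far as these compounds go, it is also open how other groups at this place would compare, such as an unsubstituted amine or a carboxylic acid, and whether any would give a number lower than that of compound 1.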